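Notes on a bromophenyl step in a weak series

The source may report more compounds than this note shows. Statements on the series, on what has been measured and on what is new or still open speak of the compounds shown alone.

- Compound 1 (`COc1cc(OC)c(-c2cc(=O)c3ccc(O)cc3o2)cc1OC`): > 150000 nM (a limit)
- Compound 2 (`COc1cc(OC)c(OC)cc1/C=C/C(=O)c1cc(Cl)ccc1O`): > 150000 nM (a limit)

In a functional assay on MCF7 cells (Homo sapiens) for inhibition, read by MTT assay, with a stated time of 72 h (a lower number here means a stronger inhibitor, a higher number a weaker inhibitor), compound 2 stands at > 150000 nM as a limit and not as a number. Compound 1 is in the same position, and the measured set rests entirely on the limit of > 150000 nM in this assay, at which 2 of the 2 values shown sit, with no numerical value to work from.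

The change from compound 2 to compound 3 (`COc1cc(OC)c(OC)cc1/C=C/C(=O)c1ccc(Br)cc1`) is 4-bromophenyl in place of 5-chloro-2-hydroxyphenyl on a carbonyl carbon and puts 4-bromophenyl in place of 5-chloro-2-hydroxyphenyl on a carbonyl carbon. In this assay, for the measured compounds named here, no measured pair shows what such a change does, so the expectation rests on little and is kept wide.

The expectation is an at least 1.8-fold lower number from compound 2 to compound 3 (0.27 log units; that floor lies within the scatter) in the direction of a stronger inhibitor, and this step is a modest one. The reading for compound 3 may well remain a limit, as both measured compounds do. Compound 3 is expected at 80000 nM (estimated range 20000 nM to 150000 nM).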

Compound 3, half-maximal inhibitory concentration: 18300 nM
The estimate for compound 3 lay 4.4-fold (0.64 log units) above the measured number; the whole stated range lies above it.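

For the compounds shown here, compound 3 gives 18300 nM in this assay, the only value in the set that is a number and not a limit. Placing 4-bromophenyl in place of 5-chloro-2-hydroxyphenyl on a carbonyl carbon brings an at least 8.1-fold lower number from compound 2 to compound 3 (0.91 log units; beyond the scatter), so the group at this position does bear on the reading, here in the direction of a stronger inhibitor. The step gives only a floor and not a size, because one end of it is a limit: the limit of > 150000 nM in this assay, at which 2 of the 3 values shown sit.

The change removes the hydroxy group, exchanges chlorine for bromine and alters where the halogen sits, all in one step, and no compound shown carries any of these changes alone, so the contribution of each remains unresolved. Also open, as far as these compounds go, is how the reading would respond on the same carbonyl carbon to a plain phenyl, a 4-chlorophenyl or a 4-aminophenyl group, any of which would show whether bromine itself matters at this position.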